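Extending two aryl-pyrrolidine acids with a fluoromethoxyphenyl ring

This account rests on a few compounds, and the source may have more. Where it says the series, first, only, none or still open, it means among the compounds named here.

Measured compounds:
compound 1 `Cc1ccccc1Cc1ccc(N2CCC[C@H]2CC(=O)O)cc1` gives 150 nM
compound 2 `Cc1ccccc1Oc1ccc(N2CCC[C@H]2CC(=O)O)cc1` gives 74 nM
compound 3 `COc1ccc(F)c(-c2cccc(Oc3ccc(N4CCC[C@H]4CC(=O)O)cc3)c2C)c1` gives 310 nM

These three compounds were tested in a functional assay on cells for agonist activity at Free fatty acid receptor 1 (Homo sapiens), read by FLIPR and calcium flux, with a stated time of 100 s; a lower number here means that less compound is needed, a higher number that more compound is needed for the effect. Compound 2 and compound 1 share a pyrrolidine acid on an aryl ring, but how their two cores differ is not broken down here. From compound 2 to compound 3 the change is 2-fluoro-5-methoxyphenyl in place of hydrogen on an aromatic carbon, and it produced a 4.2-fold higher number from compound 2 to compound 3 (0.62 log units; beyond the scatter).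

Compound 4 `COc1ccc(F)c(-c2ccc(Cc3ccc(N4CCC[C@H]4CC(=O)O)cc3)c(C)c2)c1` is not yet measured. Relative to compound 1 it carries 2-fluoro-5-methoxyphenyl in place of hydrogen on an aromatic carbon. For the measured compounds named here, this is the same kind of change as the one from compound 2 to compound 3, not the same: in compound 3 the new ring sits ortho to a methyl group and meta to a large group, whereas in compound 4 it sits meta to a methyl group and para to a large group.

The step from compound 1 to compound 4 is expected to be a 3.3-fold higher number from compound 1 to compound 4 (0.52 log units; beyond the scatter), resting on the measured 4.2-fold higher number from compound 2 to compound 3 (0.62 log units; beyond the scatter), with added uncertainty from the changed surroundings. Compound 4 is therefore estimated at 500 nM, within 150 nM to 1800 nM.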

Compound 4, half-maximal effective concentration: 220 nM
For compound 4 the middle estimate is 2.3-fold (0.36 log units) above the measured one, and the stated range covers the measured number.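

In this assay, adding the 2-fluoro-5-methoxyphenyl group to the core of compound 1 gave a 1.5-fold higher number from compound 1 to compound 4 (0.17 log units; within the scatter) and so left the number within the usual scatter on this core. Set beside the earlier step, the same change did not carry over at the same size from one core to the other: the same change on two cores in this assay, a 4.2-fold higher number (0.62 log units; beyond the scatter) from compound 2 to compound 3 and a 1.5-fold higher number (0.17 log units; within the scatter) from compound 1 to compound 4, 2.9-fold (0.46 log units) apart, beyond the scatter of two such steps. These two pairs do not show why the steps differ, since both the core and the place of the new ring change between them, and two pairs cannot separate those factors or give a rule for other cores in the series.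

The compounds shown leave open whether the two cores would respond alike with the new ring in one matching place. They also leave open how either core would respond to a pyridyl ring or a simple phenyl ring in place of the 2-fluoro-5-methoxyphenyl group.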